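From pyrimidin-2-yl to pyridin-2-yl on a sulfur

A few compounds are considered here, and "the series" means these few. Any claim that something is new, unique, unknown or untested is made for them only; others in the source may bear on it.

Values in a functional assay on PC-3 cells (Homo sapiens) for inhibition, read by MTT assay, with a stated time of 72 h (a lower number here means a stronger inhibitor, a higher number a weaker inhibitor), are as follows:
Compound 1 `FC(F)(F)c1ccc(CSc2nc(N3CCNCC3)cc(C(F)(F)F)n2)cc1` gives 15900 nM
Compound 2 `CN1CCN(c2cc(C(F)(F)F)nc(SCc3ccc(C(F)(F)F)cc3)n2)CC1` gives 34700 nM
Compound 3 `FC(F)(F)c1ccc(CSc2nc(Sc3ncccn3)cc(C(F)(F)F)n2)cc1` gives > 50000 nM as a limit

Compound 3 thus has no number in this assay and stands only at its limit of > 50000 nM on these data. Compound 4 `FC(F)(F)c1ccc(CSc2nc(Sc3ccccn3)cc(C(F)(F)F)n2)cc1` differs from compound 3 in one place (pyridin-2-yl in place of pyrimidin-2-yl on a sulfur): pyridin-2-yl in place of pyrimidin-2-yl on a sulfur.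

Among the compounds with values here, no measured step alters this ring alone. Two steps bring in the whole (pyrimidin-2-yl)sulfanyl group on an aromatic carbon (an at least 3.1-fold higher number from compound 1 to compound 3 (0.49 log units; beyond the scatter)) and (an at least 1.4-fold higher number from compound 2 to compound 3 (0.15 log units; that floor lies within the scatter)). The remaining step (a 2.2-fold higher number from compound 1 to compound 2 (0.34 log units; beyond the scatter)) is methyl in place of hydrogen on an amine nitrogen in a ring, which neither compound 3 nor compound 4 carries. None of these gives a size for a change inside the sulfanyl group, and compound 3 offers only a limit as a starting point.

The expected step in this assay is a number no higher from compound 3 to compound 4 (the limit leaves the size open) and no step beyond the scatter is expected in either direction. For compound 4 the estimated value is 50000 nM with an expected range from 25000 nM to 100000 nM.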

Compound 4, half-maximal inhibitory concentration: 25200 nM
The estimate for compound 4 lay 2.0-fold (0.30 log units) above the measured number; low and high end bracket the measured number.
By their numbers in this assay, from the lowest: compounds 1, 4 and 2 (each within the scatter of the next, the first and the last beyond it). At a limit, above all of these: compound 3.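

In this assay, a sulfanyl-linked aromatic ring at this place on the shared core now has a number to read, whereas compound 3 stands only at a limit: the limit of > 50000 nM in this assay, at which 1 of the 4 values shown sits. The change on the sulfur gives an at least 1.9-fold lower number from compound 3 to compound 4 (0.29 log units; that floor lies within the scatter), and with that floor inside the scatter, the size of the exchange of pyrimidin-2-yl for pyridin-2-yl, and even whether it is a real step, stays unsettled. Within the data shown here, the (pyridin-2-yl)sulfanyl group also shows that a piperazine is not the only group at this aromatic carbon to give a number in this assay's reach: the exchange gives a 1.4-fold lower number from compound 2 to compound 4 (0.14 log units; within the scatter) and a 1.6-fold higher number from compound 1 to compound 4 (0.20 log units; within the scatter), both within the scatter, so compound 4 cannot be ranked against either amine.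

The compounds shown leave open how far compound 3 really lies from compound 4, since one end of that comparison is a limit. They also leave open how a plain phenyl ring on this sulfur, or a morpholine or an open-chain amine on the aromatic carbon, would read against these values.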